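This account rests on a few compounds, and the source may have more. Where it says the series, first, only, none or still open, it means among the compounds named here.

The measured compounds are compound 1 `CCCc1ccc(NC2=CC(=O)c3c(nc4n3[C@H]3OC[C@@H](O)[C@H]3OC4)C2=O)cc1` with 1920 nM, compound 2 `CCc1ccc(NC2=CC(=O)c3nc4n(c3C2=O)[C@H]2OC[C@@H](O)[C@H]2OC4)cc1` with 1290 nM, and compound 3 `O=C1C(NCc2ccccc2)=CC(=O)c2c1nc1n2[C@H]2OC[C@@H](O)[C@H]2OC1` with 3490 nM.

In a functional assay on MGC-803 cells (Homo sapiens) for inhibition, read by sulforhodamine B assay (on this read-out lower numbers stand for stronger inhibition and higher numbers for weaker inhibition), compound 2 gives the lowest of the three numbers; its gap to compound 1 lies within the usual scatter, while its gap to compound 3 lies beyond it. Compound 4 `O=C1C=C(N2CCCC2)C(=O)c2c1nc1n2[C@H]2OC[C@@H](O)[C@H]2OC1` is the next compound to be tested in this assay. It differs from compound 2 in one place: pyrrolidin-1-yl in place of (4-ethylphenyl)amino on a double-bonded ring carbon.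

Among the measured compounds shown here, only one measured step bears on this change, a 1.8-fold higher number from compound 1 to compound 3 (0.26 log units; within the scatter), which exchanged one substituent on the amine nitrogen for another while keeping that nitrogen and its hydrogen in place. That step was within the scatter. The change to compound 4 goes further: the hydrogen-bond donor disappears together with the aromatic ring, and a five-membered non-aromatic ring takes their place. For the measured compounds named here, no measured pair shows what removing the donor does here. A modest move toward a higher number, beyond the scatter, is therefore expected, with wide uncertainty.

Compound 4 is estimated at 3200 nM, with a range from 1100 nM to 9500 nM. The expected step is a 2.5-fold higher number from compound 2 to compound 4 (0.39 log units; beyond the scatter).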

Compound 4, half-maximal inhibitory concentration: > 16000 nM
Compound 4: a limit, no number (the forecaster's own chance of this, stated with the estimate: 10%); at least 5.0-fold (0.69 log units) between middle value and limit.
By their numbers in this assay, from the lowest: compounds 2, 1 and 3 (each within the scatter of the next, the first and the last beyond it). At a limit, above all of these: compound 4.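

On the double-bonded ring carbon, pyrrolidin-1-yl in place of (4-ethylphenyl)amino gives a large step in this assay: an at least 12-fold higher number from compound 2 to compound 4 (1.09 log units; beyond the scatter). The only earlier step at this amine nitrogen, a 1.8-fold higher number from compound 1 to compound 3 (0.26 log units; within the scatter), kept the nitrogen and its hydrogen and stayed within the scatter, so compound 4 is the first of these compounds to show that a change at this place can cost much of the inhibition seen here. The reading for compound 4 is a limit of the assay and not a number, so the true size of the step stays unknown: the limit of > 16000 nM in this assay, at which 1 of the 4 values shown sits.

The compounds shown leave open whether the loss goes with the aromatic ring or with the hydrogen-bond donor, since both leave together in this one change. A cyclopentylamino group, which keeps the amine hydrogen and gives up the aromatic ring, and a (4-ethylphenyl)amino group carrying a methyl on its nitrogen, which keeps the aromatic ring and gives up that hydrogen, would tell the two apart.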